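A few compounds are considered here, and "the series" means these few. Any claim that something is new, unique, unknown or untested is made for them only; others in the source may bear on it.

Measured so far in a functional assay on BJAB cells (Homo sapiens) for antiproliferative activity, with a stated time of 4 days; on this read-out lower numbers stand for an effect already at smaller amounts and higher numbers for an effect only at larger amounts of compound:
compound 1 `Cc1c(-c2cc(Cl)cc(Cl)c2)c(C(=O)O)nn1-c1nc(-c2cnn(C)c2)c(SC(C)C)s1` gives "not active" (no number reported);
compound 2 `Cc1nn(-c2nc(-c3ccc(Cl)c(Cl)c3)c(SC(C)C)s2)c(C(=O)O)c1-c1cccc(F)c1` gives 900 nM;
compound 3 `Cc1c(-c2cc(Cl)cc(Cl)c2)c(C(=O)O)nn1-c1nc(-c2ccncc2)c(SC(C)C)s1` gives "not active" (no number reported).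

Compound 2 thus stands as the only one of the three with a number in this assay; compound 1 and compound 3 came back without one. Compound 4 `Cc1nn(-c2nc(-c3ccc(Cl)c(Cl)c3)c(SC(C)C)s2)c(C(=O)O)c1-c1cccc(C(F)(F)F)c1` differs from compound 2 in a single place: trifluoromethyl in place of fluoro on an aromatic carbon. For the measured compounds named here, no measured pair here shows this kind of change, so there is nothing to gauge its size from. The expected step, a 1.1-fold higher number from compound 2 to compound 4 (0.05 log units; within the scatter), is therefore small, within the usual scatter, and in no fixed direction. On that basis compound 4 is estimated at 1000 nM in this assay, with a range from 300 nM to 3500 nM.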

Compound 4, half-maximal effective concentration: 22000 nM
Compound 4: the middle estimate sits 22-fold (1.34 log units) below what was measured; the measured number lies above the stated range.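

In this assay, trifluoromethyl in place of fluoro on this aromatic carbon brings a 24-fold higher number from compound 2 to compound 4 (1.39 log units; beyond the scatter) and shows that this place on the ring is not indifferent to what sits there. The earlier compounds shown here offered no pair to show this, and the change adds no ring, hydrogen-bond donor or acceptor, or net charge. Nothing available here explains the loss of effect. From the compounds shown here alone, how a methoxy group or an amine at this place would fare remains open. A single pair also sets no trend for other groups.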